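The source may hold more compounds than are shown below. What is called first, only, known or untested is meant among the compounds shown, and "the series" means these compounds.

Measured in a functional assay on the whole organism for inhibition, with Rattus norvegicus as the target, with a stated time of 1 h (a higher number here means that more compound is needed for the effect, a lower number that less compound is needed), as follows
- compound 1 `CC1(C)OC(/C=C/c2ccccc2)=CC1=O` gives 17 mg/kg
- compound 2 `CC1(C)OC(/C=C/c2ccc(Br)cc2)=CC1=O` gives 18 mg/kg
- compound 3 `CC1(C)OC(/C=C/c2ccc(F)cc2F)=CC1=O` gives 11 mg/kg

The value of compound 3 lies within the usual scatter of the values of both compound 1 and compound 2, so the three measurements do not separate.

The next compound is compound 4 `CC1(C)OC(/C=C/c2ccc(F)cc2)=CC1=O`, reached from compound 3 by one change: hydrogen in place of fluoro on an aromatic carbon. In words, hydrogen takes the place of fluoro on an aromatic carbon, and the other fluoro group stays.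

For the measured compounds named here, only one measured step differs in a single place, the bromo in place of hydrogen on an aromatic carbon. That step, a 1.1-fold higher number from compound 1 to compound 2 (0.02 log units; within the scatter), is small and does not involve fluoro. Going by the values given here, no measured step isolates the fluoro group that leaves here, so the evidence is indirect. Still, the close values of compound 1, compound 2 and compound 3 give no sign of a large response to changes on this aromatic ring.

No step beyond the scatter is therefore expected in this assay, and the direction is only weakly defined. The estimated change is a 1.3-fold higher number from compound 3 to compound 4 (0.10 log units; within the scatter).

The estimate for compound 4 is 14 mg/kg, with an expected range from 8 mg/kg to 24 mg/kg.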

Compound 4, dose for half-maximal effect: 11 mg/kg
Compound 4: the middle estimate sits 1.3-fold (0.10 log units) above what was measured; measured number inside the range.
By their numbers in this assay, from the lowest: compounds 3, 4, 1 and 2 (each within the scatter of the next).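

Direct reading of a fluoro group at this site in this assay: no change at the digits printed from compound 3 to compound 4 (within the scatter), so replacing fluoro with hydrogen on the aromatic carbon ortho to a large group, while the fluoro group meta to it stays, gives no response that can be separated from the scatter. For the compounds shown here, compound 4 also allows the first comparisons of fluoro with hydrogen and with bromo on the same aromatic carbon, and a 1.5-fold lower number from compound 1 to compound 4 (0.19 log units; within the scatter) and a 1.6-fold lower number from compound 2 to compound 4 (0.21 log units; within the scatter) both remain within the scatter, so these three substituents do not separate there. No measurement at hand bears on why these values stay so close.

The ring substituents shown are limited to hydrogen, fluoro and bromo, which leaves open whether an amine, a carboxylic acid or a methoxy group on the ring would shift the dose beyond the scatter. On these data alone, the two methyl groups and the carbonyl of the shared core are the same in all four compounds, so the response to a change at either site, such as a longer chain in place of a methyl group, also remains open.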